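The compounds below may be only part of what the source reports. "The series", "measured", "known", "first", "only" and "open" are said of these compounds alone.

Working notes on the series. Compound 1 `CCCNc1nc(C)c(-c2nc3ccccc3s2)c(N[C@@H]2C[C@H](CO)[C@@H](O)[C@H]2O)n1` in an ADME assay on cells (Homo sapiens) for cytotoxicity, read by polymerase chain reaction, with a stated time of 3 days (a higher number here means that more compound is tolerated, a lower number that less compound is tolerated), gives only a limit, > 25000 nM (the limit of > 25000 nM in this assay, at which 1 of the 3 values shown sits). Compound 2 `Cc1nc(NC(C)(C)C)nc(N[C@@H]2C[C@H](CO)[C@@H](O)[C@H]2O)c1-c1nc2ccccc2s1` in this assay gives 12000 nM. Within the data shown here, compound 3 `Cc1nc(N(C)C)nc(N[C@@H]2C[C@H](CO)[C@@H](O)[C@H]2O)c1-c1nc2ccccc2s1` in this assay gives 18000 nM, which sits within the scatter of compound 2, as a 1.5-fold higher number from compound 2 to compound 3 (0.18 log units; within the scatter) shows; against compound 1 there is an at least 1.3-fold lower number from compound 1 to compound 3 (0.14 log units; that floor lies within the scatter), and an at least 2.0-fold lower number from compound 1 to compound 2 (0.31 log units; beyond the scatter) is the only step beyond the scatter. Compound 4 `Cc1nc(Nc2nccs2)nc(N[C@@H]2C[C@H](CO)[C@@H](O)[C@H]2O)c1-c1nc2ccccc2s1` differs from compound 3 by (1,3-thiazol-2-yl)amino in place of dimethylamino on an aromatic carbon. The measured steps are all small and bear only loosely on a change of this kind. A somewhat lower number is expected, a 2.3-fold lower number from compound 3 to compound 4 (0.35 log units; beyond the scatter), with compound 4 estimated at 8000 nM, within 3000 nM to 25000 nM.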

Compound 4, half-maximal cytotoxic concentration: 15000 nM
Beside the measured number, compound 4's estimate is 1.9-fold (0.27 log units) below it; the measured number falls inside the stated range.
By their numbers in this assay, from the lowest: compounds 2, 4 and 3 (each within the scatter of the next). At a limit, above all of these: compound 1.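

At this position, between two ring nitrogen atoms, an aromatic ring in the amine substituent leaves the number in this assay within the scatter of the alkylamino compounds: there is a 1.2-fold lower number from compound 3 to compound 4 (0.08 log units; within the scatter), and a 1.3-fold higher number from compound 2 to compound 4 (0.10 log units; within the scatter). Compound 1 gives only a limit, and there is an at least 1.6-fold lower number from compound 1 to compound 4 (0.22 log units; that floor lies within the scatter); this fixes no order: the limit of > 25000 nM in this assay, at which 1 of the 4 values shown sits.

Open, on these data alone, is whether a phenylamino group, a plain primary amine or a carboxylic acid at this position would give a number beyond the scatter of compound 2, compound 3 and compound 4.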